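A few compounds are considered here, and "the series" means these few. Any claim that something is new, unique, unknown or untested is made for them only; others in the source may bear on it.

Of the compounds shown here, three sharing one core have been measured in a functional assay on Huh-7 cells (Homo sapiens) for cytotoxicity, with a stated time of 48 h; on this read-out higher numbers stand for weaker inhibition and lower numbers for stronger inhibition. Compound 1 (`COc1cc(OC)c(C(=O)/C=C/c2ccccc2SC)c(OC)c1`) gives 14100 nM, compound 2 (`COc1cc(OC)c(C(=O)/C=C/c2ccccc2)c(OC)c1`) gives 15500 nM, and compound 3 (`COc1cc(OC)c(C(=O)/C=C/c2ccc(F)cc2)c(OC)c1`) gives 14600 nM. All three numbers lie within the scatter of one another, so compound 3 stands level with the other two.

The next compound is compound 4 (`COc1cc(OC)c(C(=O)/C=C/c2ccc(Br)cc2)c(OC)c1`), and the change that leads to it is bromo in place of fluoro on an aromatic carbon. In words, this is bromo in place of fluoro on an aromatic carbon, para to a large group.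

The measured step closest to this change is a 1.1-fold lower number from compound 2 to compound 3 (0.03 log units; within the scatter), where fluoro takes the place of hydrogen on an aromatic carbon, and it stays within the scatter. The other two steps, a 1.1-fold higher number from compound 1 to compound 2 (0.04 log units; within the scatter) and a 1.0-fold higher number from compound 1 to compound 3 (0.02 log units; within the scatter), both remove the methylsulfanyl group, and they also stay within the scatter. For the measured compounds named here, no measured compound carries bromo, so the data say nothing directly about it. Still, no measured change has moved the number beyond the scatter, so no step beyond the scatter is expected in this assay. The expected change is a 1.0-fold lower number from compound 3 to compound 4 (0.02 log units; within the scatter). Compound 4 is estimated at 14000 nM, with an expected range from 7500 nM to 25000 nM.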

Compound 4, half-maximal inhibitory concentration: 13900 nM
For compound 4 the middle estimate is 1.0-fold (0.00 log units) above the measured one; the range from low to high includes it.
By their numbers in this assay, from the lowest: compounds 4, 1, 3 and 2 (each within the scatter of the next).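

In this assay, exchanging fluoro for bromo on an aromatic carbon para to a large group gives a 1.1-fold lower number from compound 3 to compound 4 (0.02 log units; within the scatter), so a second halogen at this position leaves the number within the scatter. Set against plain hydrogen at the same place, bromo gives a 1.1-fold lower number from compound 2 to compound 4 (0.05 log units; within the scatter) as its step, which means that hydrogen, fluoro and bromo at this position now stand level with one another, and the larger exchange of 2-(methylsulfanyl)phenyl for 4-bromophenyl gives a 1.0-fold lower number from compound 1 to compound 4 (0.01 log units; within the scatter) and stays level too. Nothing measured here offers an explanation for why these numbers stay together.

All four compounds carry only hydrogen, a halogen or methylsulfanyl on this ring, so the compounds shown leave open whether any group on it can move the number beyond the scatter at all. A group of a different kind at this place, such as an amine or a carboxylic acid, would test that, and the methoxy groups of the shared core, identical in all four compounds, remain an open question as well.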